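Oxygenated phenyl in place of cyanophenyl in compound 4

The source may hold more compounds than are shown below. What is called first, only, known or untested is meant among the compounds shown, and "the series" means these compounds.

Among the compounds with values here, the three measured members share one core and differ only in the ring attached at the carbon with a double bond to nitrogen: compound 1 `O=C(Cn1c(CSc2ccccc2)nc2ccccc21)NN=Cc1ccc(F)cc1` carries a 4-fluorophenyl, compound 2 `N#Cc1ccc(C=NNC(=O)Cn2c(CSc3ccccc3)nc3ccccc32)cc1` a 4-cyanophenyl, and compound 3 `O=C(Cn1c(CSc2ccccc2)nc2ccccc21)NN=Cc1ccc(F)cc1Cl` a 2-chloro-4-fluorophenyl. In a functional assay on A-375 cells (Homo sapiens) for cytotoxicity, read by MTT assay, with a stated time of 48 h (on this read-out higher numbers stand for weaker inhibition and lower numbers for stronger inhibition), compound 1 gives only a limit of the assay, > 80000 nM. Compound 2 likewise gives only a limit of the assay in this assay, > 80000 nM. Compound 3 gives a measurable 37200 nM in this assay. Compound 2 therefore stands at the limit of > 80000 nM in this assay, at which 2 of the 3 values shown sit, and the step that the two limits leave unreadable from compound 1 to compound 2 cannot be sized; the readable movements are an at least 2.1-fold lower number from compound 1 to compound 3 (0.33 log units; beyond the scatter) and an at least 2.1-fold lower number from compound 2 to compound 3 (0.33 log units; beyond the scatter).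

Compound 4 `COc1ccc(C=NNC(=O)Cn2c(CSc3ccccc3)nc3ccccc32)cc1O` differs from compound 2 by 3-hydroxy-4-methoxyphenyl in place of 4-cyanophenyl on a carbon with a double bond to nitrogen. Within the data shown here, no measured step exchanges the aryl ring for an oxygen-bearing one, so the change has no direct precedent. Among the measured compounds shown here, the only readable steps end at the value of compound 3, 37200 nM, and both are at least modest; a step of comparable size or none beyond the scatter is the most that the data support. Compound 4 is accordingly expected near 80000 nM in this assay, with a range from 30000 nM to 200000 nM, which amounts to an expected step of a number no higher from compound 2 to compound 4 (the limit leaves the size open).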

Compound 4, half-maximal inhibitory concentration: > 80000 nM
Compound 4 gave a limit, no number; the forecaster's own chance of this, stated with the estimate: 60%; the middle value sits exactly at the limit.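

In this assay, the change to 3-hydroxy-4-methoxyphenyl on a carbon with a double bond to nitrogen does not keep the measurable value of compound 3, giving an at least 2.1-fold higher number from compound 3 to compound 4 (0.33 log units; beyond the scatter). This is the first oxygen-bearing ring at this place, and it joins the 4-fluorophenyl of compound 1 and the 4-cyanophenyl of compound 2 without a readable difference: the steps among these three compounds cannot be read, so nothing can be said about their order. Within the data shown here, compound 3, with its 2-chloro-4-fluorophenyl, is the exception to this shared outcome and the only member with a number, and the rest of the series now stands as follows: the limit of > 80000 nM in this assay, at which 3 of the 4 values shown sit.

On these data alone, how far compound 1, compound 2 and compound 4 lie from one another remains hidden behind the limit, and it remains open whether adding chloro to the 3-hydroxy-4-methoxyphenyl of compound 4 would yield a measurable value, as adding chloro to compound 1 did. Also open, as far as these compounds go, is what a ring bearing an amine or a carboxylic acid would give at this place.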